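The source may report more compounds than this note shows. Statements on the series, on what has been measured and on what is new or still open speak of the compounds shown alone.

Measured so far:
Compound 1 `CCCCCCc1cn([C@@H]2O[C@@H]3COP(=O)(O)O[C@H]3[C@H]2O)c(=O)nc1N` — in a functional assay on L1210 cells (Mus musculus) for cytotoxicity (a lower number here means a stronger inhibitor, a higher number a weaker inhibitor), compound 1 gives > 200 ug/mL, a limit of the assay and not a number.
Compound 2 `CCCc1cn([C@@H]2O[C@@H]3CO[PH](O)(O)O[C@H]3[C@H]2O)c(=O)nc1N` — in this assay compound 2 gives > 200 ug/mL, again a limit of the assay and not a number.

Where compound 1 stands: only a limit is known for it, and the single further value shown is a limit too; both sit at the limit of > 200 ug/mL in this assay, at which 2 of the 2 values shown sit. Within the data shown here, no step between measured compounds can be reckoned from these two values, and nothing orders compound 1 against compound 2.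

Compound 3 `CCCCc1cn([C@@H]2O[C@@H]3COP(=O)(O)O[C@H]3[C@H]2O)c(=O)nc1N` is not yet measured. It differs from compound 1 by hydrogen in place of ethyl on a saturated chain carbon, four bonds along the chain from an aromatic carbon. Since both values shown sit at the limit of > 200 ug/mL in this assay, at which 2 of the 2 values shown sit, no step beyond the scatter is expected in either direction in this assay. Compound 3 is expected to give 300 ug/mL in this assay, within 120 ug/mL to 800 ug/mL, and most likely to be reported only as a limit. The expected step is a step that the limit leaves unreadable from compound 1 to compound 3.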

Compound 3, concentration for 50% inhibition: > 200 ug/mL
Compound 3 gave a limit, no number (the forecaster's own chance of this, stated with the estimate: 85%); the middle value lies beyond the limit too.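

No step can be read from compound 1 to compound 3 in this assay, since each gives only a limit of the assay and not a number: the limit of > 200 ug/mL in this assay, at which 3 of the 3 values shown sit.

The compounds shown leave open how far each lies beyond that limit, and so whether the chain on the shared core has any bearing on the read-out.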